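Substituent on the aromatic oxygen: from compound 3 to compound 4

The source may report more compounds than this note shows. Statements on the series, on what has been measured and on what is new or still open speak of the compounds shown alone.

Measured in a functional assay (aorta) with Rattus norvegicus as the target; on this read-out higher numbers stand for higher potency (the scale is a negative logarithm) and lower numbers for lower potency:
compound 1, `COc1ccc2c(c1)C(n1ccccc1=O)=CC(C)(C)O2`: 6.55
compound 2, `CC1(C)C=C(n2ccccc2=O)c2cc(O)ccc2O1`: 5.44
compound 3, `CC1(C)C=C(n2ccccc2=O)c2cc(OCC(=O)c3ccc(F)cc3)ccc2O1`: 4.63

Compound 3 stands lowest of the three; the nearest is compound 2, at a number 0.81 log units lower from compound 2 to compound 3 (beyond the scatter), and the furthest compound 1, at a number 1.92 log units lower from compound 1 to compound 3 (beyond the scatter). Both steps onto compound 3 fall beyond the scatter, and the gap from compound 1 to compound 2 is a number 1.11 log units lower from compound 1 to compound 2 (beyond the scatter).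

Compound 4 is `CC1(C)C=C(n2ccccc2=O)c2cc(OC(=O)Nc3ccc(F)cc3)ccc2O1`. Its change from compound 3 is (4-fluorophenyl)carbamoyl in place of ((4-fluorophenyl)carbonyl)methyl on an oxygen on an aromatic ring. Within the data shown here, the steps that bear on it are those from compound 2 and compound 1 to compound 3, where a large group on that oxygen went with a lower number in this assay. Among the measured compounds shown here, compound 4 keeps a group of the same size and a fluorophenyl ring at that oxygen; no measured step tells what the hydrogen-bond donor of the carbamoyl adds. The expected step is therefore a number 0.17 log units higher from compound 3 to compound 4 (within the scatter), none beyond the scatter. Compound 4 is estimated at 4.8, with a range from 4.2 to 5.4.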

Compound 4, logarithm of the reciprocal of the active concentration, log(1/C): 5.3
The estimate for compound 4 lay 0.50 log units below the measured number; the measured number falls inside the stated range.
By their numbers in this assay, from the lowest: compound 3; then compounds 4 and 2 (each within the scatter of the next); then compound 1.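

In this assay, size alone does not set the number at this position: (4-fluorophenyl)carbamoyl and ((4-fluorophenyl)carbonyl)methyl each have 10 heavy atoms, yet exchanging them gives a number 0.67 log units higher from compound 3 to compound 4 (beyond the scatter). A large group on this oxygen therefore need not separate a compound from the hydrogen-bearing one, as the step of a number 0.14 log units lower from compound 2 to compound 4 (within the scatter) shows, while methyl keeps its lead with a number 1.25 log units lower from compound 1 to compound 4 (beyond the scatter). No measurement at hand explains the difference between the two large groups.

The compounds shown leave open whether the gain follows the amide hydrogen or the other changes in the linking atoms, which a carbamoyl group carrying methyl on its nitrogen would help to separate. They also leave open whether ethyl or a longer alkyl chain on this oxygen would stay close to methyl.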